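A Second Chloro on the Core and Melanoma Cell Growth

The compounds below may be only part of what the source reports. "The series", "measured", "known", "first", "only" and "open" are said of these compounds alone.

Compound 1, `ClCc1ccccc1Cn1cnc2c(Cl)nc(Cl)nc21`, in a functional assay on M14 cells (Homo sapiens) for cytotoxicity, read by sulforhodamine B assay, with a stated time of 48 h; on this read-out higher numbers stand for weaker inhibition of growth and lower numbers for stronger inhibition of growth: 2810 nM
Compound 2, `ClCc1ccccc1Cn1cnc2c(Cl)ncnc21`, in this assay: 3710 nM
Compound 3, `ClCc1cccc(Cn2cnc3c(Cl)ncnc32)c1`, in this assay: 3310 nM

All three measured compounds sit close together in this assay, and none can be singled out as stronger or weaker than the others. Compound 1 and compound 2 share a core and differ by chloro in place of hydrogen on an aromatic carbon; the step that this change made is a 1.3-fold lower number from compound 2 to compound 1 (0.12 log units; within the scatter). Compound 3 carries the same atoms as compound 2 joined differently, and the difference between the two cores is not broken down here.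

Compound 4, `ClCc1cccc(Cn2cnc3c(Cl)nc(Cl)nc32)c1`, has not been measured. It differs from compound 3 by chloro in place of hydrogen on an aromatic carbon, the same kind of change as from compound 2 to compound 1, made at a place described in identical words. Resting on the step of a 1.3-fold lower number from compound 2 to compound 1 (0.12 log units; within the scatter), compound 4 is expected to show a similarly small step, a 1.3-fold lower number from compound 3 to compound 4 (0.10 log units; within the scatter). The estimate for compound 4 is 2600 nM, between 1300 nM and 5200 nM.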

Compound 4, concentration for total growth inhibition: 3380 nM
The estimate for compound 4 lay 1.3-fold (0.11 log units) below the measured number; the measured number falls inside the stated range.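

The change of chloro in place of hydrogen on an aromatic carbon now gives a second step, a 1.0-fold higher number from compound 3 to compound 4 (0.01 log units; within the scatter), in this assay. The two steps agree as far as these measurements can tell: the same change on two cores in this assay, a 1.3-fold lower number (0.12 log units; within the scatter) from compound 2 to compound 1 and a 1.0-fold higher number (0.01 log units; within the scatter) from compound 3 to compound 4, 1.3-fold (0.13 log units) apart, within the scatter of two such steps. Among the compounds shown here, both are so small that this shows only that the change left the number within the scatter on both cores, not that it carries any real effect from one core to the other, and two cores say nothing about a third.

The compounds shown leave open whether an amine or a methoxy group in place of this chloro would produce a step beyond the scatter. They also leave open whether these small steps would hold in other cell lines.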